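Methyl for methoxy: the step from compound 2 to compound 3

This account rests on a few compounds, and the source may have more. Where it says the series, first, only, none or still open, it means among the compounds named here.

compound 1 `COc1cc2ncnc(Nc3cccc(C(F)(F)F)c3)c2cc1OCCCSc1nc2ccccc2o1` — 4030 nM
compound 2 `COc1ccc(Nc2ncnc3cc(OC)c(OCCCSc4nc5ccccc5o4)cc23)cc1` — 13100 nM

In a functional assay on MCF7 cells (Homo sapiens) for cytotoxicity, read by MTT assay, with a stated time of 24 h (a higher number here means a weaker inhibitor, a lower number a stronger inhibitor), compound 1 gives 4030 nM, and compound 2 gives 13100 nM. For the measured compounds named here, compound 2 holds the higher of the two numbers, and the only measured step, a 3.3-fold higher number from compound 1 to compound 2 (0.51 log units; beyond the scatter), is what separates the pair. Compound 3 `COc1cc2ncnc(Nc3ccc(C)cc3)c2cc1OCCCSc1nc2ccccc2o1` has not been measured. It differs from compound 2 in one place: methyl in place of methoxy on an aromatic carbon. No measured step changes this group in this way, so nothing shown here speaks directly to its effect. Going by the values given here, the one step available, a 3.3-fold higher number from compound 1 to compound 2 (0.51 log units; beyond the scatter), shows that exchanging the whole group on the ring nitrogen moved the number modestly, but that exchange was a different one, and it gives no direction for the present change. The expectation is therefore a small shift in this assay, if any, not beyond the scatter, which is what the estimated step of a 1.3-fold lower number from compound 2 to compound 3 (0.12 log units; within the scatter) expresses. Compound 3 is expected to give about 10000 nM, with a likely range from 4000 nM to 25000 nM.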

Compound 3, half-maximal inhibitory concentration: 12100 nM
Estimate against measurement, compound 3: 1.2-fold (0.08 log units) below, and the stated range covers the measured number.
By their numbers in this assay, from the lowest: compound 1; then compounds 3 and 2 (each within the scatter of the next).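

In this assay, putting methyl where methoxy stood, para to a large group, gives a 1.1-fold lower number from compound 2 to compound 3 (0.03 log units; within the scatter), so for this pair the readout does not separate the two groups, even though methoxy carries one more heavy atom and a hydrogen-bond acceptor. Compound 1 remains apart from both para-substituted compounds: a 3.0-fold higher number from compound 1 to compound 3 (0.48 log units; beyond the scatter) stands alongside a 3.3-fold higher number from compound 1 to compound 2 (0.51 log units; beyond the scatter), which shows that the gap to compound 1 was not tied to methoxy in particular, since it also appears with methyl. Nothing available here explains these readings or the lack of a difference between methoxy and methyl.

Compound 1 differs from compound 2 and compound 3 in both the group it carries and that group's place on the ring, so a 3-methylphenyl or a 4-(trifluoromethyl)phenyl compound would be needed to tell these two changes apart. For the compounds shown here, it also remains open whether the same position would stay as unresponsive in this assay with an amine or a carboxylic acid there, since methoxy and methyl are the only two groups compared at it so far.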